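The source may report more compounds than this note shows. Statements on the series, on what has been measured and on what is new or still open speak of the compounds shown alone.

Measured so far in a physicochemical assay for solubility; on this read-out lower numbers stand for lower solubility and higher numbers for higher solubility:
- compound 1 `Cn1nccc1-c1cc(C(F)(F)F)ccc1[C@H]1CCOc2cc(S(=O)(=O)Nc3nccs3)ccc21` gives 83000 nM
- compound 2 `Cn1nccc1-c1cc(C(F)(F)F)ccc1[C@@H]1CCOc2cc(S(=O)(=O)Nc3nccs3)ccc21` gives 65000 nM
- compound 3 `Cn1nccc1-c1cc(C(F)(F)F)ccc1[C@H]1CCOc2cc(S(=O)(=O)Nc3cnccn3)ccc21` gives 1170000 nM

Seen from the starting compound, the near step is a 1.3-fold lower number from compound 1 to compound 2 (0.11 log units; within the scatter) and the far step is a 14-fold higher number from compound 1 to compound 3 (1.15 log units; beyond the scatter) in this small set.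

Compound 4 `O=S(=O)(Nc1nccs1)c1ccc2c(c1)OCC[C@@H]2c1ccc(C(F)(F)F)cc1-c1ccc(F)nc1` is unmeasured and carries this change from compound 1: 6-fluoropyridin-3-yl in place of 1-methyl-1H-pyrazol-5-yl on an aromatic carbon with the new group ortho to a large group and meta to a trifluoromethyl group.

Among the measured compounds shown here, no measured step touches that place. The near step involves configuration alone and offers no guide here. For the measured compounds named here, the only guide to size is a 14-fold higher number from compound 1 to compound 3 (1.15 log units; beyond the scatter) at a sulfonamide nitrogen, a different place, so a smaller move is expected here. A moderately lower number in this assay is expected, as a judgement without measured precedent, and the range is kept wide for that reason. The estimated change is a 2.4-fold lower number from compound 1 to compound 4 (0.38 log units; beyond the scatter) and remains uncertain in size. For compound 4 the expected value is 35000 nM with an estimated range from 10000 nM to 120000 nM for now.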

Compound 4, solubility: 21000 nM
Compound 4: middle estimate off by 1.7-fold (0.22 log units), on the high side; the measured number falls inside the stated range.
By their numbers in this assay, from the lowest: compound 4; then compounds 2 and 1 (each within the scatter of the next); then compound 3.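

In this assay, the position on an aromatic carbon, ortho to a large group and meta to a trifluoromethyl group, now has its first reading: 6-fluoropyridin-3-yl in place of 1-methyl-1H-pyrazol-5-yl gives a 4.0-fold lower number from compound 1 to compound 4 (0.60 log units; beyond the scatter) in this series. This place on the core therefore moves the read-out beyond the scatter, as the sulfonamide nitrogen does, but in the other direction and by a smaller step than a 14-fold higher number from compound 1 to compound 3 (1.15 log units; beyond the scatter) at that nitrogen. Nothing available bears on the reason for the step at this position.

Open, on these data alone, is whether the ring exchange or the fluorine carries the step, which plain pyridin-3-yl would separate, and how a carboxylic acid or an aminomethyl group would read at this place. Also open, as far as these compounds go, is whether the step keeps its size with pyrazin-2-yl on the sulfonamide nitrogen or with the opposite configuration.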